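Allyloxy to Benzyloxy Hydroxamates on Macrophage Cells

The source may report more compounds than this note shows. Statements on the series, on what has been measured and on what is new or still open speak of the compounds shown alone.

Compound 1 `C=CCONC(=O)CN1C(=O)S/C(=C\c2ccc(C(=O)N[C@H](C(=O)OC)C(C)C)cc2)C1=O` and compound 2 `COC(=O)[C@@H](NC(=O)c1ccc(/C=C2\SC(=O)N(CC(=O)NOCc3ccccc3)C2=O)cc1)C(C)C` share one core, while compound 3 `C=CCONC(=O)Cn1cc(C(=O)NCC(=O)N[C@H](C(=O)O)C(C)C)c2ccccc21` and compound 4 `CC(C)[C@H](NC(=O)CNC(=O)c1cn(CC(=O)NOCc2ccccc2)c2ccccc12)C(=O)O` share another; the difference between the two cores is not broken down here. In a functional assay on RAW264.7 cells (Mus musculus) for inhibition, read by microscopy and resazurin assay, with a stated time of 72 h (a higher number here means a weaker inhibitor, a lower number a stronger inhibitor), compound 1 gives only a limit, > 128000 nM. Compound 2 likewise reaches only a limit of > 128000 nM in this assay. The change between them, (phenyl in place of vinyl on a saturated chain carbon bound to an oxygen on an unsaturated carbon), therefore yields a step that the two limits leave unreadable from compound 1 to compound 2. Compound 3 also stops at a limit of > 128000 nM in this assay, so that all three values sit at the limit of > 128000 nM in this assay, at which 3 of the 3 values shown sit. Compound 4 differs from compound 3 by the same change, (phenyl in place of vinyl on a saturated chain carbon bound to an oxygen on an unsaturated carbon). The expectation for compound 4 rests on compound 3 giving only the limit > 128000 nM. Compound 4 is expected to stay near that limit, with an expected step that the limit leaves unreadable from compound 3 to compound 4. Compound 4 is estimated at 150000 nM, between 40000 nM and 500000 nM.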

Compound 4, half-maximal inhibitory concentration: > 128000 nM
Compound 4 ended at the assay's limit; the forecaster's own chance of this, stated with the estimate: 85%; the middle value lies beyond the limit too.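

For the compounds shown here, compound 3 and compound 4 both end at a limit, so no step between them can be read, nor between compound 1 and compound 2. The compounds shown leave open whether benzyl in place of allyl changes inhibition on either core.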